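The source may report more compounds than this note shows. Statements on the series, on what has been measured and on what is new or still open speak of the compounds shown alone.

Measured so far:
compound 1, `COc1cc(NC(=O)c2cn(Cc3ccc(F)cc3)c3ccc(=O)[nH]c3c2=O)cc(OC)c1OC`: 868 nM
compound 2, `CN(C)c1ccc(NC(=O)c2cn(Cc3c(F)cccc3Cl)c3ccc(=O)[nH]c3c2=O)cc1`: 39 nM

In an in vitro assay on Sf21 cells for inhibition of high affinity 3',5'-cyclic-AMP phosphodiesterase 7A (Homo sapiens), read by scintillation proximity assay, with a stated time of 30 min (on this read-out higher numbers stand for weaker inhibition and lower numbers for stronger inhibition), compound 2 gives the lower of the two numbers, and compound 1 stands at 868 nM, a gap well beyond the scatter. The two differ in more than one place, so no single step can be read from them. Compound 3, `NC(=O)c1cccc(NC(=O)c2cn(Cc3c(F)cccc3Cl)c3ccc(=O)[nH]c3c2=O)c1`, is not yet measured. It differs from compound 2 in one place: 3-carbamoylphenyl in place of 4-(dimethylamino)phenyl on an amide-type nitrogen. Going by the values given here, no measured pair isolates this change, so the expectation rests on compound 2 alone. A modest loss is expected, a 3.1-fold higher number from compound 2 to compound 3 (0.49 log units; beyond the scatter), of a size that may or may not clear the scatter. For compound 3 the estimate is 120 nM, with a range from 40 nM to 400 nM.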

Compound 3, half-maximal inhibitory concentration: 44 nM
Compound 3: middle estimate off by 2.7-fold (0.44 log units), on the high side; the range from low to high includes it.
By their numbers in this assay, from the lowest: compounds 2 and 3 (each within the scatter of the next); then compound 1.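

At this position, on an amide-type nitrogen, the exchange of 4-(dimethylamino)phenyl for 3-carbamoylphenyl is tolerated in this assay with a 1.1-fold higher number from compound 2 to compound 3 (0.05 log units; within the scatter) and no separation between the two groups. The position thus accepts the hydrogen-bond donor counted in 3-carbamoylphenyl and absent from 4-(dimethylamino)phenyl, and the dimethylamino group is not required for a number of this size. Nothing measured here offers a reason for this result.

The step changes both the group and its number on the phenyl ring, so 4-carbamoylphenyl or 3-(dimethylamino)phenyl would be needed to part these two changes. On these data alone, whether a carboxylic acid or a nitrile in place of the carbamoyl group gives a similar number stays open, as does the reading of compound 1, which differs from both others in more than one place.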